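Amide series on a shared indole-bearing core: next step

The source may report more compounds than this note shows. Statements on the series, on what has been measured and on what is new or still open speak of the compounds shown alone.

Measured so far:
compound 1 `CC(C)(O)c1nc(-c2ccc(CNC(=O)c3cnc(-c4ccccn4)nc3)cc2)no1` — 23 nM
compound 2 `CN(C)CCC(=O)Nc1cncc(-c2cccc3[nH]ccc23)c1` — 340 nM
compound 3 `COCCCNC(=O)c1nc(-c2cccc3[nH]ccc23)no1` — 650 nM

In an assay for binding affinity to Hematopoietic prostaglandin D synthase (Homo sapiens), read by reporter gene assay and NMR (a lower number here means tighter binding, a higher number weaker binding), compound 1 gives 23 nM, compound 2 gives 340 nM and compound 3 gives 650 nM. Compound 2 stands second highest of the three numbers; its value sits within the scatter of that of compound 3, so no order between those two can be read, while compound 1 lies beyond the scatter on the lower side.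

The next compound, compound 4 `CCC(=O)Nc1cncc(-c2cccc3[nH]ccc23)c1`, is the same amide on the same core with one change: hydrogen in place of dimethylamino on a saturated chain carbon, two bonds along the chain from a carbonyl carbon. For the measured compounds named here, no measured pair shows this kind of change, so the direction of the step can only be guessed. The expectation is a small step in this assay toward a higher number, of a size that may not clear the scatter. For compound 4 the estimated value is 600 nM, with a range from 200 nM to 2000 nM, which means an expected step of a 1.8-fold higher number from compound 2 to compound 4 (0.25 log units; within the scatter).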

Compound 4, dissociation constant: 60 nM
Compound 4: the middle estimate sits 10-fold (1.00 log units) above what was measured, and the stated range ends above it.
By their numbers in this assay, from the lowest: compound 1; then compound 4; then compounds 2 and 3 (each within the scatter of the next).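

Working from this assay, hydrogen in place of dimethylamino on a saturated chain carbon, two bonds along the chain from a carbonyl carbon, gives a 5.7-fold lower number from compound 2 to compound 4 (0.75 log units; beyond the scatter). For the compounds shown here, this is the first single-place comparison, and it shows that the dimethylamino group is not needed for tight binding at this position, since the plain propanoyl amide binds more tightly than the (2-(dimethylamino)ethyl)carbonyl amide. No measured evidence accounts for the size or direction of this step.

Still open, on these data alone, is whether the gain comes from losing the amine nitrogen or from losing the whole group, which a hydroxyl group or a longer carbon chain at this carbon would help separate. As far as these compounds go, it is also open whether a smaller amine, such as a primary amine, would behave like dimethylamino or like hydrogen here.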